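The source may hold more compounds than are shown below. What is called first, only, known or untested is meant among the compounds shown, and "the series" means these compounds.

Measured in an ADME assay on microsomes from liver (Homo sapiens) for metabolic stability, read by LC-MS, with a stated time of 10 min; on this read-out lower numbers stand for a less stable compound and higher numbers for a more stable compound:
- Compound 1 `CN(C[C@@H]1Cc2c(cccc2N2CCNCC2)CN1)[C@H]1CCCc2cccnc21`: 94.2%
- Compound 2 `CN(C[C@H]1Cc2c(cccc2N2CCN(Cc3ccccn3)CC2)CN1)[C@H]1CCCc2cccnc21`: 4.2%
- Compound 3 `CN(C[C@H]1Cc2c(cccc2N2CCN3CCC[C@@H]3C2)CN1)[C@H]1CCCc2cccnc21`: 52.2%

Compound 2 stands lowest of the three, and the gaps to compound 3 and to compound 1 both lie beyond the scatter. Compound 4 `CN(C[C@H]1Cc2c(cccc2N2CCN(c3ncccn3)CC2)CN1)[C@H]1CCCc2cccnc21` is not yet measured. It differs from compound 2 by pyrimidin-2-yl in place of (pyridin-2-yl)methyl on an amine nitrogen in a ring, with pyrimidin-2-yl in place of (pyridin-2-yl)methyl on an amine nitrogen in a ring. Among the measured compounds shown here, no measured pair tests this change, so any forecast is uncertain. Compound 2 at 4.2% leaves little room to fall. A rise beyond the scatter is therefore expected, an estimated step of a number 23.8 percentage points higher from compound 2 to compound 4 (beyond the scatter). Compound 4 is estimated at 28%, with an expected range of 7% to 60%.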

Compound 4, percent of the compound remaining: 35.5%
Estimate against measurement, compound 4: 7.5 percentage points below; the range from low to high includes it.
By their numbers in this assay, from the lowest: compound 2; then compound 4; then compound 3; then compound 1.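

Among the compounds shown here, this is the first measured pair at this position: on the amine nitrogen in the six-membered non-aromatic ring, pyrimidin-2-yl in place of (pyridin-2-yl)methyl gives a number 31.3 percentage points higher from compound 2 to compound 4 (beyond the scatter) in this assay. The group on this nitrogen can therefore shift the read-out well beyond the scatter, even though both groups carry one six-membered aromatic ring. Nothing given here says why the step arises.

Still open, going by these compounds, is which part of the change matters, the lost methyl link or the second ring nitrogen. A pyridin-2-yl group placed directly on this nitrogen would separate the two.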